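Amide nitrogen substituent on the alkyne-linked urea series

The source may report more compounds than this note shows. Statements on the series, on what has been measured and on what is new or still open speak of the compounds shown alone.

The series shares a diaryl urea core, as in compound 1 `CNC(=O)C#Cc1ccc(NC(=O)Nc2ccc(Cl)c(C(F)(F)F)c2)cc1`, and is followed in a functional assay on MX1 cells (Homo sapiens) for inhibition, read by MTT assay, with a stated time of 120 h; a lower number here means a stronger inhibitor, a higher number a weaker inhibitor. Within the data shown here, compound 1 gives 26400 nM, the highest of the three numbers so far. Compound 3 `CNC(=O)/C=C/c1ccc(NC(=O)Nc2ccc(Cl)c(C(F)(F)F)c2)cc1` gives 13800 nM, and compound 2 `O=C(/C=C/c1ccc(NC(=O)Nc2ccc(Cl)c(C(F)(F)F)c2)cc1)NC1CCC1` gives 4530 nM. The change to compound 4 `CC(NC(=O)C#Cc1ccc(NC(=O)Nc2ccc(Cl)c(C(F)(F)F)c2)cc1)c1ccccc1` is 1-phenylethyl in place of methyl on an amide-type nitrogen. The step bearing on it is the amide nitrogen comparison within the alkene pair, a 3.0-fold higher number from compound 2 to compound 3 (0.48 log units; beyond the scatter), so a larger group on that nitrogen went with a lower number. The combined step a 5.8-fold lower number from compound 1 to compound 2 (0.77 log units; beyond the scatter) points the same way. A modest lowering is therefore expected for compound 4, about a 4.1-fold lower number from compound 1 to compound 4 (0.61 log units; beyond the scatter). Compound 4 is estimated at 6500 nM, within 2500 nM to 16000 nM.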

Compound 4, half-maximal inhibitory concentration: 12800 nM
Compound 4: middle estimate off by 2.0-fold (0.29 log units), on the low side, and the stated range covers the measured number.
By their numbers in this assay, from the lowest: compound 2; then compounds 4, 3 and 1 (each within the scatter of the next, the first and the last beyond it).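

Among these compounds, on the alkyne-linked amide, 1-phenylethyl in place of methyl on the amide-type nitrogen gives a 2.1-fold lower number from compound 1 to compound 4 (0.31 log units; beyond the scatter), the first reading of this nitrogen with the alkyne linker held fixed. The step is small but has the same direction as a 3.0-fold higher number from compound 2 to compound 3 (0.48 log units; beyond the scatter), so across these two pairs the methyl amide carries the higher number. No measurement here accounts for either step.

Open, going by these compounds, is whether the aromatic ring or the branched carbon of 1-phenylethyl matters, which a benzyl group or an unbranched alkyl chain on this nitrogen would separate. Also open, on these data alone, is how a cyclobutyl group behaves on the alkyne-linked amide.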